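Pyridazinone Aryl Swap on a Quinoline Ether Scaffold

The source may hold more compounds than are shown below. What is called first, only, known or untested is meant among the compounds shown, and "the series" means these compounds.

Compound 1 `COc1cc2c(Oc3ccc(NC(=O)c4nn(-c5ccccc5C(F)(F)F)c(=O)cc4C)cc3F)ccnc2cc1OCCCN1CCCC1` gives 100 nM in a functional assay on MKN-45 cells (Homo sapiens) for inhibition, read by MTT assay, with a stated time of 72 h; on this read-out lower numbers stand for stronger inhibition and higher numbers for weaker inhibition.
Compound 2 `COc1cc2c(Oc3ccc(NC(=O)c4nn(-c5ccccc5C(F)(F)F)c(=O)cc4C)cc3F)ccnc2cc1OCCCN1CCN(C)CC1` gives 40 nM in this assay.

Among the compounds with values here, compound 1 stands at the higher of the two numbers measured so far; the only neighbour is compound 2, reached by a 2.5-fold lower number from compound 1 to compound 2 (0.40 log units; beyond the scatter), a change confined to the amine at the end of the three-carbon chain. Compound 3 `COc1cc2c(Oc3ccc(NC(=O)c4nn(-c5ccc(F)c(F)c5)c(=O)cc4C)cc3F)ccnc2cc1OCCCN1CCCC1` differs from compound 1 elsewhere: 3,4-difluorophenyl in place of 2-(trifluoromethyl)phenyl on an aromatic nitrogen. Within the data shown here, none of the measured steps touches the aryl group on the aromatic nitrogen, so the data give no direct guidance on the size or direction of this change. Without such a precedent, the step from compound 1 to compound 3 is expected to be no change at the digits printed from compound 1 to compound 3 (within the scatter), that is, no change beyond the usual scatter. Compound 3 is therefore estimated at 100 nM in this assay, with a plausible range from 30 nM to 320 nM.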

Compound 3, half-maximal inhibitory concentration: 80 nM
The estimate for compound 3 lay 1.3-fold (0.10 log units) above the measured number, and the stated range covers the measured number.
By their numbers in this assay, from the lowest: compounds 2, 3 and 1 (each within the scatter of the next, the first and the last beyond it).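

In this assay the group on the aromatic nitrogen was exchanged with a 1.3-fold lower number from compound 1 to compound 3 (0.10 log units; within the scatter), so 3,4-difluorophenyl and 2-(trifluoromethyl)phenyl cannot be told apart at this position. The two groups differ in heavy atoms and in the placing of their substituents, yet with the pyrrolidin-1-yl chain end held fixed the read-out does not separate them. Nothing at hand accounts for this result.

Going by these compounds, whether 3,4-difluorophenyl would give the same outcome alongside the 4-methylpiperazin-1-yl chain end of compound 2 remains open. The compounds shown also leave open how unsubstituted phenyl, 4-fluorophenyl, a pyridyl ring or a small alkyl group such as methyl would read on that nitrogen.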